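Acyl and urea variants on a shared indole-methyl benzoic acid core

A few compounds are considered here, and "the series" means these few. Any claim that something is new, unique, unknown or untested is made for them only; others in the source may bear on it.

Measured so far:
compound 1 `COc1cc(C(=O)O)ccc1Cc1cn(C)c2ccc(NC(=O)NC3CCCC3)cc12` — 1120 nM
compound 2 `CCCC(CC)C(=O)Nc1ccc2c(c1)c(Cc1ccc(C(=O)O)cc1OC)cn2C` — 1830 nM

In an assay on lung parenchyma for displacement of a labelled ligand from cysteinyl leukotriene receptor 1 (Cavia porcellus) (a higher number here means a weaker inhibitor, a lower number a stronger inhibitor), compound 1 gives 1120 nM. For the measured compounds named here, compound 2 gives 1830 nM and so carries the higher of the two numbers in this assay; its only neighbour is compound 1, and the single step in this assay, a 1.6-fold higher number from compound 1 to compound 2 (0.21 log units; within the scatter), lies within the scatter, so the two values cannot be ordered with confidence.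

Compound 3 `CCCCCC(=O)Nc1ccc2c(c1)c(Cc1ccc(C(=O)O)cc1OC)cn2C` has not been measured. Relative to compound 2 the change is pentyl in place of 1-ethylbutyl on a carbonyl carbon: the branched chain on the carbonyl carbon becomes a straight chain of one fewer carbon, with no change in ring count, donors, acceptors or charge. Going by the values given here, the one measured step that bears on this region, from the cyclopentylamino of compound 1 to the 1-ethylbutyl of compound 2, was itself within the scatter. A smaller reshaping of the same chain is therefore expected to leave this assay essentially unchanged, with no step beyond the scatter in either direction.

Compound 3 is expected to give about 1600 nM in this assay, with a plausible range of 600 nM to 4500 nM, corresponding to an estimated step of a 1.1-fold lower number from compound 2 to compound 3 (0.06 log units; within the scatter).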

Compound 3, inhibition constant: 1900 nM
Estimate against measurement, compound 3: 1.2-fold (0.07 log units) below; the measured number falls inside the stated range.
By their numbers in this assay, from the lowest: compounds 1, 2 and 3 (each within the scatter of the next).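

In this assay, for the compounds shown here, the exchange on the carbonyl carbon reads a 1.0-fold higher number from compound 2 to compound 3 (0.02 log units; within the scatter) and so gives the first direct comparison of a branched chain with a straight one at this position: 1-ethylbutyl and pentyl cannot be told apart here, despite the difference in branching and in heavy atoms. The comparison with the cyclopentylamino group reads a 1.7-fold higher number from compound 1 to compound 3 (0.23 log units; within the scatter) and shows the same for a straight chain against a group with a ring and an amino nitrogen, so all three groups fall within the scatter of one another in this assay. No evidence is available to account for this flat result.

What the compounds shown leave open is whether any group at this position can move the number beyond the scatter in either direction, for example a much longer chain such as decyl, a phenyl ring, or a chain ending in a carboxylic acid or an amine. They also leave open whether the same insensitivity holds on a core other than the shared core, as all three compounds carry it unchanged.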